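The compounds below may be only part of what the source reports. "The series", "measured", "known", "first", "only" and "open" are said of these compounds alone.

Of the compounds shown here, three built on one shared core have been tested in an assay on CHO cells for displacement of a labelled ligand from adenosine receptor A3 (Homo sapiens), read by scintillation counting, with a stated time of 45 min, in the presence of a further agent that is not named here; on this read-out higher numbers stand for weaker inhibition and lower numbers for stronger inhibition. Compound 1 `CCCn1c(=O)[nH]c2nc(-c3ccc(S(=O)(=O)N4CCN(c5ccc(F)cc5)CC4)cc3)[nH]c2c1=O` gives > 1000 nM, which is a limit of the assay rather than a number. Compound 2 `CCCn1c(=O)[nH]c2nc(-c3ccc(S(=O)(=O)N4CCN(c5cccc(Br)c5)CC4)cc3)[nH]c2c1=O` gives > 1000 nM, also a limit. Compound 3 `CCCn1c(=O)[nH]c2nc(-c3ccc(S(=O)(=O)N4CCN(c5ccccc5)C(C)C4)cc3)[nH]c2c1=O` gives > 1000 nM, again a limit. Because (the limit of > 1000 nM in this assay, at which 3 of the 3 values shown sit), the step that the two limits leave unreadable from compound 1 to compound 2 cannot be read. Compound 3 thus stands at that same limit, with no number of its own. Compound 4 `CCCn1c(=O)[nH]c2nc(-c3ccc(S(=O)(=O)N4CCN(c5ccccc5)CC4)cc3)[nH]c2c1=O` has not yet been measured; it differs from compound 3 by hydrogen in place of methyl on a saturated ring carbon. No measured step informs this change, since every shown value is a limit. Compound 4 is expected to give 3000 nM in this assay, with a range from 800 nM to 30000 nM. The expected step that the limit leaves unreadable from compound 3 to compound 4 is estimated to stay within the scatter.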

Compound 4, inhibition constant: > 1000 nM
Compound 4: no number, only a limit; the forecaster's own chance of this, stated with the estimate: 85%; the middle value is on the limit's open side.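

The steps to compound 4 from compound 1, compound 2 and compound 3 cannot be read in this assay: the limit of > 1000 nM in this assay, at which 4 of the 4 values shown sit.

As far as these compounds go, the actual strength of all four compounds stays open, as does whether the fluoro, bromo or methyl changes make any difference.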